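Iodo in place of phenyl on compound 2

A few compounds are considered here, and "the series" means these few. Any claim that something is new, unique, unknown or untested is made for them only; others in the source may bear on it.

Three compounds of the series have numbers in a functional assay on M21 cells (Homo sapiens) for inhibition, read by sulforhodamine B assay, with a stated time of 48 h; a higher number here means a weaker inhibitor of growth, a lower number a stronger inhibitor of growth. Compound 1 `O=C(CCl)NC(=O)Nc1ccc2ccccc2c1` gives 3700 nM, compound 2 `O=C(CCl)NC(=O)Nc1ccc(-c2ccccc2)cc1` gives 1400 nM and compound 3 `O=C(CCl)NC(=O)Nc1cccc(Oc2ccccc2)c1` gives 5300 nM. Compound 2 has the lowest number of the three, and its gaps to compound 1 and to compound 3 both lie beyond the scatter.

Compound 4 `O=C(CCl)NC(=O)Nc1ccc(I)cc1` keeps the core of compound 2 and changes one group: iodo in place of phenyl on an aromatic carbon. Going by the values given here, no pair of measured compounds differs in one place only, so the data give no direct measure of this replacement. Since compound 2 at 1400 nM already holds the lowest number, a replacement is more likely to raise the number than to lower it. A moderate move towards weaker inhibition of growth is therefore expected in this assay, though a result within the scatter remains possible. The estimated change is a 2.9-fold higher number from compound 2 to compound 4 (0.46 log units; beyond the scatter). For compound 4 the expected value is 4000 nM, with an estimated range of 1500 nM to 12000 nM.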

Compound 4, concentration for 50% growth inhibition: 4200 nM
The estimate for compound 4 lay 1.1-fold (0.02 log units) below the measured number; the measured number falls inside the stated range.
By their numbers in this assay, from the lowest: compound 2; then compounds 1, 4 and 3 (each within the scatter of the next).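

Working from the one clean comparison in the series, replacing phenyl with iodo para to the group of 8 heavy atoms gives a 3.0-fold higher number from compound 2 to compound 4 (0.48 log units; beyond the scatter) in this assay, a modest loss of growth inhibition. Going by these compounds alone, this is the first direct reading at this position, and it shows that the phenyl of compound 2 cannot be exchanged for iodo without a change beyond the scatter, although compound 4 still has a measurable number. No measured property bears on this step, so no cause can be assigned to it.

Open, going by these compounds, is how a methoxy, an amine, a carboxylic acid or a cyclohexyl would read on this aromatic carbon. Also open, on these data alone, is whether the step holds when the chloromethyl group of the shared core gives way to a bromomethyl or a longer chain.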